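Phenyl in Place of Methoxy on the Ketone Aryl Group

A few compounds are considered here, and "the series" means these few. Any claim that something is new, unique, unknown or untested is made for them only; others in the source may bear on it.

Three compounds share one core and differ only in the aromatic group attached to a carbonyl carbon. Compound 1 `COc1cc(-c2nnc3n2NC(c2ccco2)C(C(=O)c2ccccc2C)S3)cc(OC)c1OC` carries 2-methylphenyl there, and in a functional assay on PC-3 cells (Homo sapiens) for cytotoxicity, read by MTT assay, with a stated time of 48 h (on this read-out higher numbers stand for weaker inhibition and lower numbers for stronger inhibition), compound 1 gives 88400 nM. Compound 2 `COc1cc(-c2nnc3n2NC(c2ccco2)C(C(=O)c2cccs2)S3)cc(OC)c1OC` carries thiophen-2-yl, and in this assay compound 2 gives 46200 nM; the step of a 1.9-fold lower number from compound 1 to compound 2 (0.28 log units; within the scatter) lies within the scatter. Compound 3 `COc1ccc(C(=O)C2Sc3nnc(-c4cc(OC)c(OC)c(OC)c4)n3NC2c2ccco2)cc1` carries 4-methoxyphenyl. In this assay compound 3 reaches only the limit > 100000 nM, which is a boundary of the assay and not a number. Compound 3 thus sits at that boundary: the step of an at least 1.1-fold higher number from compound 1 to compound 3 (0.05 log units; that floor lies within the scatter) lies within the scatter, while the step of an at least 2.1-fold higher number from compound 2 to compound 3 (0.33 log units; beyond the scatter) lies beyond it.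

Compound 4 `COc1cc(-c2nnc3n2NC(c2ccco2)C(C(=O)c2ccc(-c4ccccc4)cc2)S3)cc(OC)c1OC` differs from compound 3 by phenyl in place of methoxy on an aromatic carbon. Among the measured compounds shown here, no measured step swaps methoxy for phenyl; the measured steps each exchange the whole aromatic group and move by modest amounts at most. The expectation is therefore that compound 4 stays near the boundary, with a step of a number no higher from compound 3 to compound 4 (the limit leaves the size open) not expected to go beyond the scatter. Compound 4 is estimated at 100000 nM, between 35000 nM and 300000 nM.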

Compound 4, half-maximal inhibitory concentration: 45900 nM
The estimate for compound 4 lay 2.2-fold (0.34 log units) above the measured number, within the range that was stated.
By their numbers in this assay, from the lowest: compounds 4, 2 and 1 (each within the scatter of the next). At a limit, above all of these: compound 3.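

In this assay, phenyl in place of methoxy gives an at least 2.1-fold lower number from compound 3 to compound 4 (0.33 log units; beyond the scatter). Unlike the earlier steps, which exchanged the whole aromatic group, this one changes only the group on an aromatic carbon para to a large group, and it shows that a second ring can stand there without the number rising. The result only joins the other ketone aryl groups, with a 1.0-fold lower number from compound 2 to compound 4 (0.00 log units; within the scatter) and a 1.9-fold lower number from compound 1 to compound 4 (0.28 log units; within the scatter). Compound 3 gives a limit and not a number, so the full size of its step stays open: the limit of > 100000 nM in this assay, at which 1 of the 4 values shown sits.

From the compounds shown here alone, whether this place needs an aromatic ring remains open, as cyclohexyl, a fluorine atom or an amine there could behave differently from phenyl. Also open, going by these compounds, is whether phenyl in place of methoxy would give a similar step on another ketone aryl group.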